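A Second Fluorine on the Phenyl Ketone

A few compounds are considered here, and "the series" means these few. Any claim that something is new, unique, unknown or untested is made for them only; others in the source may bear on it.

In a functional assay on MKN-45 cells (Homo sapiens) for cytotoxicity, read by MTT assay, with a stated time of 48 h (a lower number here means a stronger inhibitor, a higher number a weaker inhibitor), compound 1 `COc1cc(-c2nnc(SCC(=O)c3ccccc3)n2N2C(=O)c3ccccc3C2=O)cc(OC)c1OC` reaches only the limit > 200000 nM. Within the data shown here, compound 2 `COc1cc(-c2nnc(SCC(=O)c3ccc(F)cc3)n2N2C(=O)c3ccccc3C2=O)cc(OC)c1OC` gives 126000 nM in this assay, the single number among the two values shown. Among the measured compounds shown here, the one measured step, an at least 1.5-fold lower number from compound 1 to compound 2 (0.20 log units; that floor lies within the scatter), is fluoro in place of hydrogen on an aromatic carbon, and its size is bounded only by the limit of > 200000 nM in this assay, at which 1 of the 2 values shown sits. Compound 3 `COc1cc(-c2nnc(SCC(=O)c3ccc(F)c(F)c3)n2N2C(=O)c3ccccc3C2=O)cc(OC)c1OC` differs from compound 2 by fluoro in place of hydrogen on an aromatic carbon. For the measured compounds named here, that single step, with its uncertain floor, gives the only guide, so compound 3 is expected to show a step of a 1.3-fold lower number from compound 2 to compound 3 (0.10 log units; within the scatter) that stays within the scatter. Compound 3 is therefore estimated at 100000 nM, between 50000 nM and 200000 nM.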

Compound 3, half-maximal inhibitory concentration: > 200000 nM
Compound 3: only a limit was reported; the forecaster's own chance of this, stated with the estimate: 20%; at least 2.0-fold (0.30 log units) between middle value and limit.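

Compound 3 gives > 200000 nM in this assay, and this is a limit of the assay. The second fluoro, ortho to a fluoro group, brings an at least 1.5-fold higher number from compound 2 to compound 3 (0.20 log units; that floor lies within the scatter), so the lower number of compound 2 does not recur at this new place, although that floor stays within the scatter. The step between the two compounds at the limit cannot be read, and the ends of the series stay unsized: the limit of > 200000 nM in this assay, at which 2 of the 3 values shown sit.

As far as these compounds go, it remains open whether an amine or a nitrile at this place would give a readable number.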